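The compounds below may be only part of what the source reports. "The series", "measured", "known", "first", "only" and "open" are said of these compounds alone.

Measured so far in a functional assay on K562 cells (Homo sapiens) for antiproliferative activity, read by sulforhodamine B assay, with a stated time of 48 h; on this read-out lower numbers stand for stronger inhibition and higher numbers for weaker inhibition:
compound 1, `COc1cccc(NS(=O)(=O)c2ccc(N3CCNC3=O)cc2)c1`, 230 nM
compound 2, `Cc1cc(C)cc(NS(=O)(=O)c2ccc(N3CCNC3=O)cc2)c1`, 110 nM
compound 3, `Cc1cccc(NS(=O)(=O)c2ccc(N3CCNC3=O)cc2)c1`, 200 nM

Compound 3 sits close to both of its neighbours on this read-out: there is a 1.2-fold lower number from compound 1 to compound 3 (0.06 log units; within the scatter), and a 1.8-fold higher number from compound 2 to compound 3 (0.26 log units; within the scatter), neither of which exceeds the scatter. Among the measured compounds shown here, the only step that is clearly beyond the scatter is a 2.1-fold lower number from compound 1 to compound 2 (0.32 log units; beyond the scatter), which changes two positions at once.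

Compound 4, `Cc1ccc(C)c(NS(=O)(=O)c2ccc(N3CCNC3=O)cc2)c1`, carries the change (methyl in place of hydrogen on an aromatic carbon), read one bond further out as 3-methylphenyl becoming 2,5-dimethylphenyl. For the measured compounds named here, the step that bears most directly on it is the one from compound 2 to compound 3, where a methyl was removed from the aryl ring and the number moved only within the scatter. Going by the values given here, no measured step puts a methyl at this particular carbon, so the evidence is indirect. A small move toward a lower number, not beyond the scatter, is expected, namely a 1.3-fold lower number from compound 3 to compound 4 (0.10 log units; within the scatter). For compound 4 the estimate in this assay is 160 nM, with a range from 80 nM to 320 nM.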

Compound 4, half-maximal inhibitory concentration: 72 nM
Compound 4: middle estimate off by 2.2-fold (0.35 log units), on the high side; measured number outside the range, below it.
By their numbers in this assay, from the lowest: compounds 4, 2, 3 and 1 (each within the scatter of the next, the first and the last beyond it).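

In this assay, a methyl on the aromatic carbon ortho to a large group and para to a methyl group gives a 2.8-fold lower number from compound 3 to compound 4 (0.44 log units; beyond the scatter), a step beyond the scatter, whereas the methyl change in a 1.8-fold higher number from compound 2 to compound 3 (0.26 log units; within the scatter) stayed within it. The two dimethylphenyl compounds cannot be separated, since 2,5-dimethylphenyl in place of 3,5-dimethylphenyl gives a 1.5-fold lower number from compound 2 to compound 4 (0.18 log units; within the scatter), within the scatter. The widest step among the four compounds is a 3.2-fold lower number from compound 1 to compound 4 (0.50 log units; beyond the scatter), and nothing measured here explains why this carbon responds as it does.

From the compounds shown here alone, it remains open whether an ethyl, an amine or a carboxylic acid on this carbon would keep the number this low. Also open, going by these compounds, is what a methyl here does on a ring without the second methyl.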